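This account rests on a few compounds, and the source may have more. Where it says the series, first, only, none or still open, it means among the compounds named here.

Measured so far in an ADME assay on HEp-2 cells (Homo sapiens) for cytotoxicity; on this read-out higher numbers stand for lower toxicity in this test and lower numbers for higher toxicity in this test:
- compound 1 `Cc1ccc(NC(=O)CNS(=O)(=O)c2cccc3cccnc23)c(C)c1`: > 50000 nM (a limit of the assay, not a number)
- compound 2 `Cc1cccc(NC(=O)[C@@H]2CCCN2S(=O)(=O)c2cccc3cccnc23)c1`: 25500 nM
- compound 3 `CC(C)c1ccccc1NC(=O)[C@@H]1CCCN1S(=O)(=O)c1cccc2cccnc12`: 29900 nM

For the measured compounds named here, compound 3, at 29900 nM, lies within the scatter of compound 2, the only other compound with a true number. Compound 4 `O=C(Nc1ccc(Cl)cc1Cl)[C@@H]1CCCN1S(=O)(=O)c1cccc2cccnc12` carries 2,4-dichlorophenyl in place of 2-isopropylphenyl on an amide-type nitrogen. Going by the values given here, one measured step bears on this place: a 1.2-fold higher number from compound 2 to compound 3 (0.07 log units; within the scatter). That step changed the group on the same nitrogen and stayed within the scatter, so no step beyond the scatter is expected in this assay. The estimated change is a 1.2-fold lower number from compound 3 to compound 4 (0.06 log units; within the scatter), which is no real shift in either direction. Compound 4 is expected at 26000 nM, with an estimated range from 11000 nM to 50000 nM.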

Compound 4, half-maximal cytotoxic concentration: > 50000 nM
Compound 4: no number, only a limit; the forecaster's own chance of this, stated with the estimate: 15%; at least 1.9-fold (0.28 log units) between middle value and limit.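

In this assay compound 4 gives > 50000 nM, which is a limit of the assay and not a number. Placing 2,4-dichlorophenyl on the amide-type nitrogen brings an at least 1.6-fold higher number from compound 3 to compound 4 (0.22 log units; that floor lies within the scatter) and an at least 1.9-fold higher number from compound 2 to compound 4 (0.29 log units; that floor lies within the scatter), so this change at this place is not shown to go beyond the scatter, though it could. The true size of both steps stays unknown because the read-out stops at a limit: the limit of > 50000 nM in this assay, at which 2 of the 4 values shown sit.

The compounds shown leave open how the number would move with an amine or a carboxylic acid on the aromatic ring of this group.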